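The source may hold more compounds than are shown below. What is called first, only, known or untested is meant among the compounds shown, and "the series" means these compounds.

Measured compounds:
- compound 1 `C=CC(=O)Nc1cc(Nc2nc3c(c(-c4cn(C)c5ccc(F)cc45)n2)CSCC3)c(OC)cc1N(C)CCN(C)C`: 4550 nM
- compound 2 `CCC/C=C\C(=O)Nc1cc(Nc2nc3c(c(-c4cn(C)c5ccc(F)cc45)n2)CSCC3)c(OC)cc1N(C)CCN(C)C`: 5190 nM
- compound 3 `C=CC(=O)Nc1cc(Nc2nc3c(c(-c4cn(C)c5ccccc45)n2)CSCC3)c(OC)cc1N(C)CCN(C)C`: 506 nM

All three values come from a functional assay on A549 cells (Homo sapiens) for inhibition, read by MTT assay, with a stated time of 72 h; a lower number here means a stronger inhibitor, a higher number a weaker inhibitor. In this set, compound 3, at 506 nM, has the lowest number. Putting hydrogen in place of fluoro on an aromatic carbon gave a 9.0-fold lower number from compound 1 to compound 3 (0.95 log units; beyond the scatter). That is a large move, but it is a different change from the one considered here, so it says little about what follows.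

Compound 4 `C/C=C\C(=O)Nc1cc(Nc2nc3c(c(-c4cn(C)c5ccccc45)n2)CSCC3)c(OC)cc1N(C)CCN(C)C` has not yet been measured. It differs from compound 3 in one place: prop-1-en-1-yl in place of vinyl on a carbonyl carbon. In words, this is prop-1-en-1-yl in place of vinyl on a carbonyl carbon.

Among the compounds with values here, the closest precedent is pent-1-en-1-yl in place of vinyl at that same carbonyl carbon, which gave a 1.1-fold higher number from compound 1 to compound 2 (0.06 log units; within the scatter). That is a swap of the same kind, and its size lies within the scatter. Within the data shown here, it is only one example, though, and it was seen with the fluoro group present, so some uncertainty remains.

No clear shift is therefore expected in this assay, and the expected result is a 1.1-fold higher number from compound 3 to compound 4 (0.04 log units; within the scatter). For compound 4 the estimated value is 560 nM, with an expected range of 260 nM to 1250 nM.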

Compound 4, half-maximal inhibitory concentration: 6860 nM
Beside the measured number, compound 4's estimate is 12-fold (1.09 log units) below it; the measured number lies above the stated range.
By their numbers in this assay, from the lowest: compound 3; then compounds 1, 2 and 4 (each within the scatter of the next).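

The carbonyl carbon turns out not to be a position where any change of this kind passes unnoticed: without the fluoro group, prop-1-en-1-yl in place of vinyl gives a 14-fold higher number from compound 3 to compound 4 (1.13 log units; beyond the scatter) in this assay. The related swap with the fluoro group present gave only a 1.1-fold higher number from compound 1 to compound 2 (0.06 log units; within the scatter), so the calm result at this position in that pair does not carry over to the pair without fluoro, and one swap at a position cannot stand for every parent compound. Nothing available here explains why the two pairs differ so much.

Two pieces would separate the effect of the group from that of its setting: pent-1-en-1-yl on the fluoro-free core of compound 3, and prop-1-en-1-yl on the fluoro-bearing core of compound 1. The compounds shown also leave open whether a different group on this carbonyl carbon, such as a chain ending in an amine, would keep a number as low as that of compound 3 or would move it as prop-1-en-1-yl did.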